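Swapping the amide aryl ring: a weaker inhibitor expected

The source may report more compounds than this note shows. Statements on the series, on what has been measured and on what is new or still open speak of the compounds shown alone.

Of the compounds shown here, three sharing one core have been measured in a functional assay on MDA-MB-231 cells (Homo sapiens) for antiproliferative activity, read by CCK-8 assay, with a stated time of 72 h; a lower number here means a stronger inhibitor, a higher number a weaker inhibitor. Compound 3 `O=C(Nc1cccc(-c2oc3cc(-c4ccc(F)cc4)ccc3c(=O)c2O)c1)c1cccc(F)c1` gives 2510 nM, the lowest of the three numbers. Compound 1 `O=C(Nc1cccc(-c2oc3cc(-c4ccc(F)cc4)ccc3c(=O)c2O)c1)c1ccccc1F` gives 7240 nM, and compound 2 `O=C(Nc1cccc(-c2oc3cc(-c4ccc(F)cc4)ccc3c(=O)c2O)c1)c1ccc(Br)cc1` gives 24900 nM. All steps among them lie beyond the scatter: a 2.9-fold lower number from compound 1 to compound 3 (0.46 log units; beyond the scatter), a 3.4-fold higher number from compound 1 to compound 2 (0.54 log units; beyond the scatter) and a 9.9-fold lower number from compound 2 to compound 3 (1.00 log units; beyond the scatter).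

Compound 4 `COc1ccc(C(=O)Nc2cccc(-c3oc4cc(-c5ccc(F)cc5)ccc4c(=O)c3O)c2)c(F)c1` differs from compound 3 in one place: 2-fluoro-4-methoxyphenyl in place of 3-fluorophenyl on a carbonyl carbon. Among the measured compounds shown here, two measured steps bear on this. The step of a 2.9-fold lower number from compound 1 to compound 3 (0.46 log units; beyond the scatter) shows that a 2-fluorophenyl gave a higher number than a 3-fluorophenyl on this carbonyl carbon, and compound 4 carries a 2-fluoro-4-methoxyphenyl. The step of a 3.4-fold higher number from compound 1 to compound 2 (0.54 log units; beyond the scatter) shows that a 4-bromophenyl gave a higher number still. Both steps point toward a weaker inhibitor, so compound 4 is expected to give a higher number than compound 3 in this assay, by about a 3.2-fold higher number from compound 3 to compound 4 (0.50 log units; beyond the scatter). The estimate for compound 4 in this assay is 8000 nM, within a range from 2500 nM to 25000 nM.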

Compound 4, half-maximal inhibitory concentration: 17600 nM
Beside the measured number, compound 4's estimate is 2.2-fold (0.34 log units) below it, and the stated range covers the measured number.
By their numbers in this assay, from the lowest: compound 3; then compound 1; then compounds 4 and 2 (each within the scatter of the next).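

In this assay, methoxy in place of hydrogen on an aromatic carbon is a single addition to the 2-fluorophenyl ring, and it gives a weaker inhibitor: a 2.4-fold higher number from compound 1 to compound 4 (0.39 log units; beyond the scatter). Among the compounds shown here, the whole swap of 3-fluorophenyl for 2-fluoro-4-methoxyphenyl on this carbonyl carbon costs a 7.0-fold higher number from compound 3 to compound 4 (0.85 log units; beyond the scatter), a loss larger than the one seen with the 2-fluorophenyl ring alone, while a 1.4-fold lower number from compound 2 to compound 4 (0.15 log units; within the scatter) leaves compound 4 and compound 2 indistinguishable, so the first group here that is not a lone halogen brings no gain over the 3-fluorophenyl ring. No measurement given here accounts for these shifts.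

Still open, on these data alone, is whether a methoxy on a ring without fluorine, or an unsubstituted phenyl, would behave the same way on this carbonyl carbon. Also open, as far as these compounds go, is how a ring carrying an amine or a carboxylic acid would compare with the 3-fluorophenyl ring of compound 3.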